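Fluoro for propyl in a herbicidal urea series

The source may hold more compounds than are shown below. What is called first, only, known or untested is meant among the compounds shown, and "the series" means these compounds.

Compound 2 `CCCc1ccc(NC(=O)N[C@H](C)c2ccccc2)cc1` gives 35% in an ADME assay on the whole organism with Oryza sativa as the target, tested at 10 uM (on this read-out higher numbers stand for a weaker effect at the one concentration tested and lower numbers for a stronger effect), the lowest of the three numbers shown. Compound 1 `CC(C)c1cccc(NC(=O)N[C@H](C)c2ccccc2)c1` gives 44%, within the scatter of compound 2. Compound 3 `CCCc1ccc(NC(=O)N[C@@H](C)c2ccccc2)cc1` gives 73%, and the shift a number 38 percentage points higher from compound 2 to compound 3 (beyond the scatter) is large, because the fact that compounds 2 and 3 differ only in the configuration as drawn is the only difference between the two. Compound 4 `C[C@@H](NC(=O)Nc1ccc(F)cc1)c1ccccc1` differs from compound 2 by fluoro in place of propyl on an aromatic carbon. Within the data shown here, none of the measured steps touches this kind of change; the single step measured concerns configuration only, so no size or direction can be drawn from it. Compound 4 is therefore expected to come out near its parent, with an estimated step of a number 10 percentage points higher from compound 2 to compound 4 (within the scatter). The estimate for compound 4 in this assay is 45%, within a range from 20% to 75%.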

Compound 4, a percentage reported as activity, at one concentration (the size of the read-out at that concentration, not a potency): 92%
Beside the measured number, compound 4's estimate is 47 percentage points below it, and the stated range ends below it.
By their numbers in this assay, from the lowest: compounds 2 and 1 (each within the scatter of the next); then compound 3; then compound 4.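

In this assay, fluoro in place of propyl on an aromatic carbon, para to a large group, gives a weaker effect: a number 57 percentage points higher from compound 2 to compound 4 (beyond the scatter). Among these compounds, this shows that the read-out responds to the group at this position, whereas the only earlier step concerned configuration. Nothing at hand explains this step.

On these data alone, it remains open whether fluoro itself or the absence of the propyl chain accounts for the step. A methyl or ethyl chain, or a chlorine or methoxy group, at this carbon could separate the two.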